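Replacing the 3-methylphenyl Group of Compound 2

The source may report more compounds than this note shows. Statements on the series, on what has been measured and on what is new or still open speak of the compounds shown alone.

In a functional assay on A549 cells (Homo sapiens) for antiproliferative activity, read by MTT assay, with a stated time of 48 h (on this read-out lower numbers stand for stronger inhibition and higher numbers for weaker inhibition), compound 1 `COc1cc(-c2cccc3nc(-c4ccc(Br)cc4)oc23)cc(OC)c1OC` gives only a limit, > 25000 nM. Within the data shown here, compound 2 `COc1cc(-c2cccc3nc(-c4cccc(C)c4)oc23)cc(OC)c1OC` gives 16700 nM, the only actual number available. Among the measured compounds shown here, the single measured step, an at least 1.4-fold lower number from compound 1 to compound 2 (0.17 log units; that floor lies within the scatter), stays within the scatter and so offers little guide to size. Compound 3 `COc1cc(-c2nc3cccc(-c4cc(OC)c(OC)c(OC)c4)c3o2)ccc1O` carries a different change: 4-hydroxy-3-methoxyphenyl in place of 3-methylphenyl on an aromatic carbon. For the measured compounds named here, no measured step covers this new group, so only a small move towards a lower number is expected, a 2.1-fold lower number from compound 2 to compound 3 (0.32 log units; beyond the scatter). For compound 3, the estimated value in this assay is 8000 nM, with an expected range from 1500 nM to 25000 nM.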

Compound 3, half-maximal inhibitory concentration: 15700 nM
Estimate against measurement, compound 3: 2.0-fold (0.29 log units) below; low and high end bracket the measured number.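

In this assay, the position on the five-membered aromatic ring tolerates a hydroxy and methoxy-bearing phenyl as readily as a methylphenyl: a 1.1-fold lower number from compound 2 to compound 3 (0.03 log units; within the scatter). A hydrogen-bond donor and acceptors thus enter at this place without a change in the read-out that can be told from scatter. The step of an at least 1.5-fold lower number from compound 1 to compound 3 (0.20 log units; that floor lies within the scatter) adds no clear gain, and its starting point is a limit, not a number: the limit of > 25000 nM in this assay, at which 1 of the 3 values shown sits.

On these data alone, whether the hydroxy or the methoxy group matters alone remains open. So does whether an amine or a carboxylic acid on this phenyl ring would move the number beyond the scatter.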